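Series notes: the step from compound 3 to compound 4

This account rests on a few compounds, and the source may have more. Where it says the series, first, only, none or still open, it means among the compounds named here.

Measured compounds, with values in a functional assay for inhibition of sodium/hydrogen exchanger (Oryctolagus cuniculus); a lower number here means a stronger inhibitor, a higher number a weaker inhibitor:
compound 1 `Cc1cc(-c2ccc(F)cc2)c(S(C)(=O)=O)cc1C(=O)N=C(N)N`: 36 nM
compound 2 `Cc1cc(-c2ccccc2)c(S(C)(=O)=O)cc1C(=O)N=C(N)N`: 19 nM
compound 3 `Cc1cc(Nc2cccc(Cl)c2)c(S(C)(=O)=O)cc1C(=O)N=C(N)N`: 33 nM

Compound 3 gives the second highest of the three numbers; its nearest neighbour is compound 1, with a 1.1-fold lower number from compound 1 to compound 3 (0.04 log units; within the scatter), and its furthest is compound 2, with a 1.7-fold higher number from compound 2 to compound 3 (0.24 log units; within the scatter). Compound 4 `Cc1ccc(S(C)(=O)=O)cc1C(=O)N=C(N)N` differs from compound 3 by hydrogen in place of (3-chlorophenyl)amino on an aromatic carbon. Among the measured compounds shown here, no measured step removes this group outright; the three that touch the position, a 1.9-fold lower number from compound 1 to compound 2 (0.28 log units; within the scatter), a 1.1-fold lower number from compound 1 to compound 3 (0.04 log units; within the scatter) and a 1.7-fold higher number from compound 2 to compound 3 (0.24 log units; within the scatter), each exchange one group for another and all stay within the scatter. Removal to hydrogen is a larger change with no direct precedent, so a higher number is expected for compound 4, of about a 9.1-fold higher number from compound 3 to compound 4 (0.96 log units; beyond the scatter), with wide uncertainty. The estimate for compound 4 is 300 nM, in the range 60 nM to 1500 nM.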

Compound 4, half-maximal inhibitory concentration: 150 nM
For compound 4 the middle estimate is 2.0-fold (0.30 log units) above the measured one; the range from low to high includes it.
By their numbers in this assay, from the lowest: compounds 2, 3 and 1 (each within the scatter of the next); then compound 4.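

In this assay, the position ortho to a methylsulfonyl group proves sensitive to having a substituent at all, which swaps among the three groups had not shown: with hydrogen there, the shift is a 4.5-fold higher number from compound 3 to compound 4 (0.66 log units; beyond the scatter) for (3-chlorophenyl)amino, a 7.9-fold higher number from compound 2 to compound 4 (0.90 log units; beyond the scatter) for phenyl and a 4.2-fold higher number from compound 1 to compound 4 (0.62 log units; beyond the scatter) for 4-fluorophenyl, each beyond the scatter. Aryl and arylamino groups therefore both give lower numbers than hydrogen here. Still open, as far as these compounds go, is whether a small group, such as methyl, methoxy or a simple amine, would do the same. Nothing measured accounts for the difference.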